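Trimming the Aryl Group from a Thiazole Amide Series

The compounds below may be only part of what the source reports. "The series", "measured", "known", "first", "only" and "open" are said of these compounds alone.

Measured so far:
compound 1, `COc1ccc(-c2cnc(NC(=O)CCCCCCNC(=O)C(O)(O)C(F)(F)F)s2)cc1`: 930 nM
compound 2, `COc1ccc2nc(NC(=O)CCCCCCNC(=O)C(O)(O)C(F)(F)F)sc2c1`: 7560 nM

Both compounds were tested in a functional assay on HCT-116 cells (Homo sapiens) for inhibition, read by colorimetric assay, with a stated time of 3 days; on this read-out higher numbers stand for weaker inhibition and lower numbers for stronger inhibition. Compound 1 gives the lowest number of the two; compound 2 returns a higher number, and the gap between them is beyond the scatter of repeated measurements. Among the compounds with values here, no step between the two measured compounds is counted here, since they differ in more than one place, so only their two values can be compared.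

The unmeasured compound 3, `O=C(CCCCCCNC(=O)C(O)(O)C(F)(F)F)Nc1nccs1`, keeps the whole amide chain and the five-membered ring of compound 1 but drops the aryl substituent: hydrogen in place of 4-methoxyphenyl on an aromatic carbon. Because compound 1 shows 930 nM while carrying the 4-methoxyphenyl, and compound 2, which also carries an additional fused aromatic portion, sits higher, the loss of the entire aryl group is expected to move this assay in the direction of weaker inhibition, by a step well beyond the scatter.

For compound 3 the estimated result in this assay is 12000 nM, with a range from 3000 nM to 50000 nM, corresponding to an expected step of a 13-fold higher number from compound 1 to compound 3 (1.11 log units; beyond the scatter).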

Compound 3, half-maximal inhibitory concentration: 10800 nM
For compound 3 the middle estimate is 1.1-fold (0.05 log units) above the measured one; measured number inside the range.
By their numbers in this assay, from the lowest: compound 1; then compounds 2 and 3 (each within the scatter of the next).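

In this assay, the change of 4-methoxyphenyl to hydrogen on the aromatic carbon next to the ring sulfur gives a 12-fold higher number from compound 1 to compound 3 (1.06 log units; beyond the scatter), a large step in the direction of weaker inhibition. Within the data shown here, this is the first comparison that differs in one place only, so it ties the gap to this position: with the rest of compound 1 unchanged, removing the aryl group, with its six-membered aromatic ring of carbon only and its single hydrogen-bond acceptor, costs much of the inhibition seen on this read-out. No measurement here explains why the aryl group matters at this position, and the step by itself gives no reason for it.

The compounds shown leave open whether the six-membered aromatic ring alone carries the step or whether the methoxy group contributes too, a question that a plain phenyl group or a 4-chlorophenyl group at this position would address. They also leave open whether a small group such as methyl on the same carbon would recover any of the step, and how a shorter or longer chain would behave with the 4-methoxyphenyl in place.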